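A few compounds are considered here, and "the series" means these few. Any claim that something is new, unique, unknown or untested is made for them only; others in the source may bear on it.

Among the measured compounds shown here, in a functional assay on HL-60 cells (Homo sapiens) (a higher number here means that more compound is needed for the effect, a lower number that less compound is needed), only two compounds have been measured so far. Compound 1 `COc1ccc(-c2ccc(-c3cc(OC)cc(OC)c3)cc2)cc1` gives > 100000 nM, which is a limit of the assay and not a number. For the measured compounds named here, compound 2 `COc1cc(OC)cc(-c2cccc(-c3ccc(O)cc3)c2)c1` gives 23000 nM, the only actual number available, so it has no numerical neighbour to be ranked against. Compound 3 `COc1ccc(-c2cccc(-c3cc(OC)cc(OC)c3)c2)cc1` has not yet been measured. It differs from compound 2 by a single change methyl in place of hydrogen on an oxygen on an aromatic ring, which turns 4-hydroxyphenyl to 4-methoxyphenyl. Going by the values given here, no measured pair isolates this change, so its size in this assay can only be judged loosely. Compound 1 also carries 4-methoxyphenyl and stands at the limit of > 100000 nM. The core of compound 1 differs as well, which makes this a weak hint. A moderate rise in the number is therefore expected, meaning that more compound would be needed. The estimate corresponds to an expected 2.2-fold higher number from compound 2 to compound 3 (0.34 log units; beyond the scatter). For compound 3 the estimated value is 50000 nM, with an expected range of 18000 nM to 100000 nM.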

Compound 3, concentration for half-maximal activity: > 100000 nM
Compound 3: only a limit was reported; the forecaster's own chance of this, stated with the estimate: 35%; at least 2.0-fold (0.30 log units) between middle value and limit.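

Among the compounds shown here, this gives the first pair that isolates the change at this oxygen: in this assay, methyl in place of hydrogen, which turns 4-hydroxyphenyl to 4-methoxyphenyl on an otherwise unchanged compound, gives an at least 4.3-fold higher number from compound 2 to compound 3 (0.63 log units; beyond the scatter). Compound 3 gives > 100000 nM, which is a limit of the assay and not a number. The step therefore shows that the hydroxy form at this position needs less compound than the methoxy form by a margin beyond the scatter, but it fixes only a lower bound on the size of that margin, and the true size cannot be read from the data: the limit of > 100000 nM in this assay, at which 2 of the 3 values shown sit.

The compounds shown leave open how far compound 3 really lies from compound 2, and whether the core of compound 1 makes any difference to the methoxy form, since that comparison cannot be read with both compounds at the limit. They also leave open what other groups would do at this place, such as an amine or a carboxylic acid in place of the hydroxy, or an ethyl in place of the methyl.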